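Fluoro to Trifluoromethyl on Two Related Cores

The compounds below may be only part of what the source reports. "The series", "measured", "known", "first", "only" and "open" are said of these compounds alone.

Measured compounds:
Compound 1, `CC(CSc1ccc(F)cc1)C(=O)Nc1ccc([N+](=O)[O-])cc1C(F)(F)F`, 43200 nM
Compound 2, `CC(CSc1ccc(C(F)(F)F)cc1)C(=O)Nc1ccc([N+](=O)[O-])cc1C(F)(F)F`, 54300 nM
Compound 3, `CC(CS(=O)(=O)c1ccc(F)cc1)C(=O)Nc1ccc([N+](=O)[O-])c(C(F)(F)F)c1`, 2670 nM

In a functional assay on LNCaP cells (Homo sapiens) for antiproliferative activity, read by MTT assay, with a stated time of 96 h (on this read-out lower numbers stand for stronger inhibition and higher numbers for weaker inhibition), compound 1 gives 43200 nM and compound 2 gives 54300 nM. The two share a core and differ by trifluoromethyl in place of fluoro on an aromatic carbon. This change brings a 1.3-fold higher number from compound 1 to compound 2 (0.10 log units; within the scatter), so on this core the two values cannot be told apart.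

Compound 3 has a different core; how that core differs from the core of compound 1 is not broken down here. In this assay compound 3 gives 2670 nM, the lowest of the three numbers, and its distance to both compound 1 and compound 2 lies beyond the scatter.

Compound 4, `CC(CS(=O)(=O)c1ccc(C(F)(F)F)cc1)C(=O)Nc1ccc([N+](=O)[O-])c(C(F)(F)F)c1`, has not yet been measured. It relates to compound 3 by trifluoromethyl in place of fluoro on an aromatic carbon, the same kind of change as that from compound 1 to compound 2, and the place of the change reads the same in both cases. Going by the values given here, the only guide is the step on the first core, which is within the scatter. The step from compound 3 to compound 4 is therefore expected to be small, a 1.3-fold higher number from compound 3 to compound 4 (0.12 log units; within the scatter), because the matching change gave a 1.3-fold higher number from compound 1 to compound 2 (0.10 log units; within the scatter). Whether the second core carries the change the same way is not known, so the range is kept wide. For compound 4 the estimate in this assay is 3500 nM, with a band from 1500 nM to 9000 nM.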

Compound 4, half-maximal inhibitory concentration: 3310 nM
Compound 4: the middle estimate sits 1.1-fold (0.02 log units) above what was measured; low and high end bracket the measured number.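

In this assay, the change from 4-fluorophenyl to 4-(trifluoromethyl)phenyl on the core of compound 3 brings a 1.2-fold higher number from compound 3 to compound 4 (0.09 log units; within the scatter). Set beside the earlier step on the core of compound 1, the same change reads alike on both cores: the same change on two cores in this assay, a 1.3-fold higher number (0.10 log units; within the scatter) from compound 1 to compound 2 and a 1.2-fold higher number (0.09 log units; within the scatter) from compound 3 to compound 4, 1.0-fold (0.01 log units) apart, within the scatter of two such steps. This shows that, for these two pairs, the change carried from one core to the other without a step beyond the scatter on either, but two pairs make no rule for other cores, and neither step separates a small real shift from none at all, nor do they say which of the differences between the two cores would matter for a larger series.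

The compounds shown carry only fluoro and trifluoromethyl at this place, so it remains open how a chloro group, a methoxy group, an amine or a carboxylic acid would read there on either core. Also open, from the compounds shown here alone, is whether the two steps would stay alike if the nitro group gave way to a nitrile, or if the methyl group on the chain gave way to a longer chain.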